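The compounds below may be only part of what the source reports. "The series", "measured", "known", "first", "only" and "open" are said of these compounds alone.

Measured so far:
Compound 1 `Cn1nnnc1SCC(=O)N/N=C/c1ccc(C(F)(F)F)cc1` gives > 10000000 nM in an ADME assay on NIH3T3 cells (Mus musculus) for cytotoxicity, read by XTT assay, with a stated time of 24 h (a lower number here means a stronger inhibitor, a higher number a weaker inhibitor), which is a limit of the assay and not a number.
Compound 2 `Cn1nnnc1SCC(=O)N/N=C/c1ccccc1F` gives 2000000 nM.

Within the data shown here, compound 2 thus stands as the only compound with a numeric value in this assay; the other value is a limit (the limit of > 10000000 nM in this assay, at which 1 of the 2 values shown sits). Compound 3 `COc1ccccc1/C=N/NC(=O)CSc1nnnn1C` differs from compound 2 by methoxy in place of fluoro on an aromatic carbon. Among the measured compounds shown here, no step between measured compounds is available for comparison, so the expected step is a 1.5-fold higher number from compound 2 to compound 3 (0.18 log units; within the scatter), within the scatter and of no settled direction. Compound 3 is therefore estimated to give 3000000 nM in this assay, with a range from 1000000 nM to 10000000 nM.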

Compound 3, half-maximal inhibitory concentration: 3160000 nM
The estimate for compound 3 lay 1.1-fold (0.02 log units) below the measured number; low and high end bracket the measured number.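

Putting methoxy in place of fluoro on this aromatic carbon, ortho to a large group, gives in this assay a 1.6-fold higher number from compound 2 to compound 3 (0.20 log units; within the scatter). The change adds a hydrogen-bond acceptor and one heavy atom, yet the step stays within the scatter, so at this place the two groups cannot be told apart. Compound 1 stands at a limit and not a number: the limit of > 10000000 nM in this assay, at which 1 of the 3 values shown sits.

On these data alone, what an amine or a carboxylic acid on this carbon would give stays open. So does whether a larger change here would move the number beyond the scatter.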